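The source may hold more compounds than are shown below. What is called first, only, known or untested is meant among the compounds shown, and "the series" means these compounds.

For the measured compounds named here, compound 2 `O=c1c(-c2ccc(O)cc2)coc2cc(OCCCCCCO)ccc12` is the one compound of the pair that yields a measured number: in an assay (Cricetulus griseus) for inhibition of aldehyde dehydrogenase, mitochondrial (Homo sapiens) (a higher number here means a weaker inhibitor, a lower number a stronger inhibitor), compound 2 gives 120 nM. Compound 1 `O=C(O)CCCCCCCCCCCCCCCOc1ccc2c(=O)c(-c3ccc(O)cc3)coc2c1` returns only a limit of the assay, since in this assay compound 1 reaches > 9000 nM. Going by the values given here, the single measured step, an at least 75-fold lower number from compound 1 to compound 2 (1.87 log units; beyond the scatter), rests on that limit, as recorded in the limit of > 9000 nM in this assay, at which 1 of the 2 values shown sits. Compound 3 `O=C(O)CCCCCCCCCOc1ccc2c(=O)c(-c3ccc(O)cc3)coc2c1` differs from compound 2 by 3-carboxypropyl in place of hydroxy on a saturated chain carbon, six bonds along the chain from an oxygen on an aromatic ring. The 3-carboxypropyl group is shorter than the 9-carboxynonyl group of compound 1, so compound 3 reverses, in a shorter form, the change behind an at least 75-fold lower number from compound 1 to compound 2 (1.87 log units; beyond the scatter), and a step toward weaker inhibition is expected for compound 3, though not necessarily as far as the limit. The expected step is a 17-fold higher number from compound 2 to compound 3 (1.22 log units; beyond the scatter). Compound 3 is therefore estimated at 2000 nM, within a range of 400 nM to 9000 nM.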

Compound 3, half-maximal inhibitory concentration: 50 nM
Beside the measured number, compound 3's estimate is 40-fold (1.60 log units) above it; measured number outside the range, below it.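

With 3-carboxypropyl in place of hydroxy at this chain carbon, the number in this assay falls rather than rises, a 2.4-fold lower number from compound 2 to compound 3 (0.38 log units; beyond the scatter), so a chain ending in a carboxylic acid does not by itself cost inhibition at this position. The two acids also part widely, an at least 180-fold lower number from compound 1 to compound 3 (2.25 log units; beyond the scatter), with carboxy in place of 6-carboxyhexyl, so the loss seen earlier goes with the longer of the two chains and not with the acid end. The value of compound 1 is a limit of the assay and not a number, and this step rests on it: the limit of > 9000 nM in this assay, at which 1 of the 3 values shown sits.

The compounds shown do not separate the effect of the carboxylic acid from that of the added chain length, which a hydroxy-ended chain as long as that of compound 3 would address. They also leave open where between the two acid chains inhibition is lost, and how an amine or an amide at the chain end would read.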